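Removing the Amino Group from Compound 1

The compounds below may be only part of what the source reports. "The series", "measured", "known", "first", "only" and "open" are said of these compounds alone.

Of the compounds shown here, three from this study have so far been read in an ADME assay on BHK cells (Mesocricetus auratus) for cytotoxicity, read by MTT assay, with a stated time of 96 h; on this read-out lower numbers stand for higher toxicity in this test and higher numbers for lower toxicity in this test. Compound 1 `COc1ccc(-c2nc3cc(Cl)c(Cl)cc3[nH]2)c(N)c1` gives > 100000 nM there, which is a limit of the assay and not a number. Compound 2 `COc1ccc(-c2nc3cc(C(C)=O)ccc3[nH]2)c(OC)c1OC` likewise gives > 100000 nM in this assay, again a limit. Compound 3 `O=C(CN1CCCC1)Nc1ccc(-c2nc3cc(C(F)(F)F)ccc3[nH]2)cc1` is the only one of the three with a measured number, giving 29000 nM in this assay. Compound 1 therefore stands at the limit of > 100000 nM in this assay, at which 2 of the 3 values shown sit, alongside compound 2, while compound 3 alone falls inside the measured range. Within the data shown here, no step between two measured compounds that differ in one place is available, so nothing among the measured values shows how a single change moves this read-out.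

Compound 4 `COc1ccc(-c2nc3cc(Cl)c(Cl)cc3[nH]2)cc1` has not yet been measured. It differs from compound 1 in one place: hydrogen in place of amino on an aromatic carbon. Because compound 1 gives > 100000 nM in this assay, the expectation for compound 4 starts from that edge of the assay. The step from compound 1 to compound 4 is expected to be a number no higher from compound 1 to compound 4 (the limit leaves the size open), that is, no change beyond the scatter. Compound 4 is accordingly estimated at 100000 nM, with a range from 30000 nM to 300000 nM, and a good chance that only a limit is reported again.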

Compound 4, half-maximal cytotoxic concentration: 18000 nM
Estimate against measurement, compound 4: 5.6-fold (0.74 log units) above; measured number outside the range, below it.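

In this assay, hydrogen in place of amino gives an at least 5.5-fold lower number from compound 1 to compound 4 (0.74 log units; beyond the scatter). Among these compounds, this is the first step between two measured compounds that differ in one place, and it shows that this position, ortho to a large group and meta to a methoxy group, is not indifferent: the change moves the read-out beyond the scatter, towards higher toxicity in this test. Going by these compounds, the full size of the step remains open on one side, as compound 1 is read only as a limit of the assay and not as a number: the limit of > 100000 nM in this assay, at which 2 of the 4 values shown sit.

The compounds shown leave open whether the amino group is special here or whether another group at this position, such as a hydroxyl group or a methyl group, would also keep the read-out at the limit. They also leave open whether the same change would move the read-out in the same direction on a core carrying trifluoromethyl in place of the two chlorine atoms.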